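From Two Sulfonyl Groups to One: Expecting Compound 4

This account rests on a few compounds, and the source may have more. Where it says the series, first, only, none or still open, it means among the compounds named here.

Of the compounds shown here, three on a shared core have been tested in a functional assay on cells (Neutrophil, Homo sapiens) for inhibition, read by WST assay, with a stated time of 20 min; a lower number here means a stronger inhibitor, a higher number a weaker inhibitor. Compound 1 `Cc1ccc2c(n1)C(=O)C(Cl)=C(Cl)C2=O` gives 3400 nM in this assay. Compound 2 `O=C1C(NC(c2ccccc2)c2ccccc2)=C(Cl)C(=O)c2ncccc21` gives 33900 nM in this assay. Compound 3 `Cc1ccc(S(=O)(=O)C2=C(S(=O)(=O)c3ccc(C)cc3)C(=O)c3ncccc3C2=O)cc1` reaches only a limit of this assay, > 200000 nM, so no true number is known for it. That places compound 3 on (the limit of > 200000 nM in this assay, at which 1 of the 3 values shown sits), the one position among the three where no measurable inhibition was recorded.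

Compound 4 `Cc1ccc(S(=O)(=O)C2=C(Cl)C(=O)c3ncccc3C2=O)cc1` has not been measured. It differs from compound 3 by chloro in place of (4-methylphenyl)sulfonyl on a double-bonded ring carbon, so compound 4 carries one chloro on the core, as compound 2 does, and compound 2 gives 33900 nM. Within the data shown here, no step between two measured compounds that differ in a single place is available, so the expectation rests on this comparison alone. Compound 4 is expected to inhibit more strongly than compound 3, a step of an at least 6.6-fold lower number from compound 3 to compound 4 (0.82 log units; beyond the scatter), although the true size cannot be fixed while compound 3 has only a limit. The estimate for compound 4 is 30000 nM, with a range from 8000 nM to 150000 nM.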

Compound 4, half-maximal inhibitory concentration: > 200000 nM
Compound 4 gave a limit, no number; the forecaster's own chance of this, stated with the estimate: 20%; middle value at least 6.6-fold (0.82 log units) from the limit.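

Among these compounds, no step from compound 3 to compound 4 can be read, since each gives only a limit and no true number: the limit of > 200000 nM in this assay, at which 2 of the 4 values shown sit. The compounds shown leave open how strongly either one inhibits, and whether chloro in place of (4-methylphenyl)sulfonyl changes inhibition at all.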